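Cyclohexyl-benzimidazole imidazopyrazines: ortho-fluoro replaces ortho-methoxy

The compounds below may be only part of what the source reports. "The series", "measured", "known", "first", "only" and "open" are said of these compounds alone.

Measured so far:
compound 1 `c1ccc(-c2cn3ccnc3c(-c3ccc4ncn(C5CCCCC5)c4c3)n2)cc1` — 38%
compound 2 `CC(=O)c1ccc(-c2cn3ccnc3c(-c3ccc4ncn(C5CCCCC5)c4c3)n2)cc1` — 12%
compound 3 `COc1ccccc1-c1cn2ccnc2c(-c2ccc3ncn(C4CCCCC4)c3c2)n1` — 8.4%

In a functional assay on MCF7 cells (Homo sapiens) for inhibition, read by sulforhodamine B assay, with a stated time of 48 h, tested at 10 uM (a higher number here means more inhibition at the concentration tested (going by the name of the read-out), a lower number less inhibition), compound 3 gives the lowest of the three numbers; compound 2 sits within the scatter of it, and only compound 1 stands clearly apart, the step being a number 29.6 percentage points lower from compound 1 to compound 3 (beyond the scatter). Compound 4 `Fc1ccccc1-c1cn2ccnc2c(-c2ccc3ncn(C4CCCCC4)c3c2)n1` is not yet measured. It differs from compound 3 by fluoro in place of methoxy on an aromatic carbon; the group sits on an aromatic carbon of a six-membered aromatic ring of carbon only.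

Among the measured compounds shown here, two measured steps bear on this. Adding a group to the unsubstituted phenyl of compound 1 lowered the read-out in both cases: a number 26 percentage points lower from compound 1 to compound 2 (beyond the scatter) and a number 29.6 percentage points lower from compound 1 to compound 3 (beyond the scatter), while the exchange a number 3.6 percentage points lower from compound 2 to compound 3 (within the scatter) stayed within the scatter. For the measured compounds named here, no compound carries fluoro, so the direction of swapping methoxy for fluoro rests on no direct comparison. Because a number 29.6 percentage points lower from compound 1 to compound 3 (beyond the scatter) shows that the methoxy substituent carries the whole drop from compound 1, a smaller single-atom substituent is expected to recover part of it, giving a step of a number 9.6 percentage points higher from compound 3 to compound 4 (within the scatter) in this assay.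

Compound 4 is therefore estimated at 18%, with a range from 5% to 36%.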

Compound 4, a percentage reported as inhibition, at one concentration (the size of the read-out at that concentration, not a potency): 11.2%
Estimate against measurement, compound 4: 6.8 percentage points above; measured number inside the range.
By their numbers in this assay, from the lowest: compounds 3, 4 and 2 (each within the scatter of the next); then compound 1.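

In this assay, fluoro in place of methoxy on this aromatic carbon, ortho to a large group, gives a number 2.8 percentage points higher from compound 3 to compound 4 (within the scatter), so removing one heavy atom and the hydrogen-bond acceptor of methoxy brings no readable difference. Even the single fluorine atom gives a number 26.8 percentage points lower from compound 1 to compound 4 (beyond the scatter), so the drop from compound 1 is now seen with fluoro as well as with methoxy and acetyl, and a number 0.8 percentage points lower from compound 2 to compound 4 (within the scatter) shows no readable difference between 2-fluorophenyl and 4-acetylphenyl. No measurement shown here explains these steps.

Open, going by these compounds, is whether an amine or a carboxylic acid on this ring would also sit clearly under compound 1. Single-concentration read-outs also leave the potency of these compounds undefined.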